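Amide ring swap on the shared core: expectation for compound 4

The source may hold more compounds than are shown below. What is called first, only, known or untested is meant among the compounds shown, and "the series" means these compounds.

Measured in an assay on HEK293 cells for agonist activity at Bile acid receptor (Homo sapiens), read by a luciferase reporter; a lower number here means a smaller maximal response, a higher number a larger maximal response:
compound 1 `CC(C)OC(=O)C1CN(C(=O)c2cccc(Cl)c2)CC(C)(C)c2cc(C#N)[nH]c21` gives 103%
compound 2 `CC(C)OC(=O)C1CN(C(=O)C2CCCCC2)CC(C)(C)c2cc(C#N)[nH]c21` gives 127%
compound 3 `CC(C)OC(=O)C1CN(C(=O)c2ccc(Cl)cc2)CC(C)(C)c2cc(C#N)[nH]c21` gives 115%

Compound 3 stands second highest of the three: the step of a number 12 percentage points higher from compound 1 to compound 3 (beyond the scatter) puts it above compound 1, and the step of a number 12 percentage points lower from compound 2 to compound 3 (beyond the scatter) puts it below compound 2.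

Compound 4 `CC(C)OC(=O)C1CN(C(=O)C2CCOCC2)CC(C)(C)c2cc(C#N)[nH]c21` differs from compound 3 by oxan-4-yl in place of 4-chlorophenyl on a carbonyl carbon. Within the data shown here, the steps that bear on this are the change from an aromatic to a saturated ring on the same carbonyl carbon, a number 24 percentage points higher from compound 1 to compound 2 (beyond the scatter), and its counterpart a number 12 percentage points lower from compound 2 to compound 3 (beyond the scatter). Among the measured compounds shown here, both point to a modest rise in this assay for a saturated ring; the ring oxygen has no precedent among the measured compounds, so a smaller step is expected. Compound 4 is expected to give 124%, with a range of 105% to 145%. The expected step is a number 9 percentage points higher from compound 3 to compound 4 (within the scatter).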

Compound 4, largest response reached (reported as efficacy), in percent of the reference or control that the assay uses: 112%
For compound 4 the middle estimate is 12 percentage points above the measured one; the measured number falls inside the stated range.
By their numbers in this assay, from the lowest: compounds 1, 4 and 3 (each within the scatter of the next, the first and the last beyond it); then compound 2.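

In this assay a saturated ring on this carbonyl carbon does not by itself keep the response of the cyclohexyl amide: oxan-4-yl in place of cyclohexyl reads a number 15 percentage points lower from compound 2 to compound 4 (beyond the scatter). Against the two chlorophenyl amides the oxan-4-yl amide does not separate, with a number 3 percentage points lower from compound 3 to compound 4 (within the scatter) and a number 9 percentage points higher from compound 1 to compound 4 (within the scatter). Nothing measured here accounts for these steps.

Still open, from the compounds shown here alone, is whether a ring amine such as piperidin-4-yl would behave like oxan-4-yl or like cyclohexyl. Also open, going by these compounds, is how an open chain such as pentyl, or a carboxylic acid on the cyclohexyl ring, would read.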